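A few compounds are considered here, and "the series" means these few. Any claim that something is new, unique, unknown or untested is made for them only; others in the source may bear on it.

Measured in a functional assay on SK-BR-3 cells (Homo sapiens) for cytotoxicity, read by resazurin assay, with a stated time of 72 h; on this read-out lower numbers stand for stronger inhibition and higher numbers for weaker inhibition:
- compound 1 `O=S(=O)(O)CCCSC(=S)NCc1cccnc1`: 6770 nM
- compound 2 `CC1(C)OB(CCCSC(=S)NCc2cccnc2)OC1(C)C`: 6820 nM
- compound 3 `COc1ccc(-c2nnc(CCSC(=S)NCc3cccnc3)o2)cc1`: 2960 nM

Compound 3 has the lowest number of the three, and its gaps to compound 1 and to compound 2 both lie beyond the scatter. Compound 1 at 6770 nM and compound 2 at 6820 nM sit close together.

The next compound is compound 4 `S=C(NCc1cccnc1)SCCc1nnc(-c2cccs2)o1`. It differs from compound 3 at one place, with thiophen-2-yl in place of 4-methoxyphenyl on an aromatic carbon of the five-membered aromatic ring with 2 nitrogen and 1 oxygen: thiophen-2-yl in place of 4-methoxyphenyl on an aromatic carbon.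

Among the measured compounds shown here, no pair of measured compounds differs in one place only, so this change has no direct precedent. The expectation rests on the narrow spread of the values, from compound 3 at 2960 nM to compound 2 at 6820 nM. In this assay, a small move towards a higher number is expected, probably none beyond the scatter. The expected step is a 1.2-fold higher number from compound 3 to compound 4 (0.07 log units; within the scatter). For compound 4 the estimated value is 3500 nM, with an expected range from 1500 nM to 7500 nM.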

Compound 4, half-maximal inhibitory concentration: 1070 nM
Compound 4: middle estimate off by 3.3-fold (0.51 log units), on the high side, outside the stated range (below it).
By their numbers in this assay, from the lowest: compound 4; then compound 3; then compounds 1 and 2 (each within the scatter of the next).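

In this assay, among the compounds shown here, the group on this aromatic carbon of the five-membered aromatic ring with 2 nitrogen and 1 oxygen gives the first single change that can be read, and the change is not neutral: thiophen-2-yl in place of 4-methoxyphenyl gives a 2.8-fold lower number from compound 3 to compound 4 (0.44 log units; beyond the scatter) and the step lies beyond the scatter. The exchange replaces a six-membered aromatic ring of carbon only, with 8 heavy atoms, by a five-membered aromatic ring with 1 hetero atom, with 5 heavy atoms, while the counts of hydrogen-bond donors and acceptors stay the same, and the smaller group gives the lower number in this pair. For the compounds shown here, no measurement on these compounds bears on the origin of the step, and only its size and direction are established.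

Plain phenyl or furan-2-yl at the same carbon would help separate the loss of the methoxy group from the change of ring size and hetero atom. The compounds shown also leave open whether the step holds when thiophen-2-yl is paired with a longer chain between the sulfur and the five-membered aromatic ring.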